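A few compounds are considered here, and "the series" means these few. Any claim that something is new, unique, unknown or untested is made for them only; others in the source may bear on it.

Compound 1 `C=CC1=C(C(=O)NCCC)C(c2ccc(F)cc2)OC1` is the starting point. In a functional assay on SW480 cells (Homo sapiens) for cytotoxicity, read by MTT assay, with a stated time of 24 h (on this read-out higher numbers stand for weaker inhibition and lower numbers for stronger inhibition), compound 1 gives > 100000 nM, which is a limit of the assay rather than a number. Its nearest measured neighbour is compound 2 `C=CC1=C(C(=O)O)C(c2ccc(F)cc2)OC1`, in which a hydroxy takes the place of the propylamino on the carbonyl carbon. In this assay compound 2 also gives > 100000 nM, again a limit. The step from compound 1 to compound 2 is therefore a step that the two limits leave unreadable from compound 1 to compound 2, because of the limit of > 100000 nM in this assay, at which 2 of the 2 values shown sit, so it tells nothing about direction or size.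

The unmeasured compound 3 `C=CC1=C(C(=O)NCc2ccc(Cl)cc2)C(c2ccc(F)cc2)OC1` keeps the core of compound 1 and changes only the amide side chain: 4-chlorophenyl in place of ethyl on a saturated chain carbon bound to an amide-type nitrogen, so the propyl becomes a 4-chlorobenzyl. Within the data shown here, no measured step bears on this kind of change, and the single measured step, from compound 1 to compound 2, is unreadable. With compound 1 sitting at the limit, the expected step from compound 1 to compound 3 is estimated as a number no higher from compound 1 to compound 3 (the limit leaves the size open), with no readable direction. For compound 3 the estimate in this assay is 100000 nM, within a range from 30000 nM to 300000 nM, and most likely it will again be reported only as a limit.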

Compound 3, half-maximal inhibitory concentration: > 100000 nM
Compound 3 was reported as a limit (the forecaster's own chance of this, stated with the estimate: 70%); the middle value sits exactly at the limit.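

Among these compounds, replacing the propyl of compound 1 with the 4-chlorobenzyl of compound 3 gives no step that can be read, because the results for compound 1, compound 2 and compound 3 are all limits rather than numbers: the limit of > 100000 nM in this assay, at which 3 of the 3 values shown sit. The compounds shown leave open whether any change to the amide side chain affects the result in this assay.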